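Adding a Second Methoxy to the Anilide of Compound 3

A few compounds are considered here, and "the series" means these few. Any claim that something is new, unique, unknown or untested is made for them only; others in the source may bear on it.

Measured so far in an ADME assay on L02 cells (Homo sapiens) for cytotoxicity, read by MTT assay, with a stated time of 72 h; a higher number here means a weaker inhibitor, a lower number a stronger inhibitor:
compound 1, `O=C(O)CCC(=O)OCCCCCCSc1ccc([N+](=O)[O-])c2nonc12`: 1890 nM
compound 2, `O=C(CCC(=O)OCCCCCCSc1ccc([N+](=O)[O-])c2nonc12)Nc1ccccc1`: 6490 nM
compound 3, `COc1ccccc1NC(=O)CCC(=O)OCCCCCCSc1ccc([N+](=O)[O-])c2nonc12`: 4490 nM

Compound 3 gives the second highest of the three numbers. Its nearest neighbour is compound 2, with a 1.4-fold lower number from compound 2 to compound 3 (0.16 log units; within the scatter). Compound 1 stands further away, with a 2.4-fold higher number from compound 1 to compound 3 (0.38 log units; beyond the scatter).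

Compound 4, `COc1ccc(NC(=O)CCC(=O)OCCCCCCSc2ccc([N+](=O)[O-])c3nonc23)cc1OC`, differs from compound 3 in one place: 3,4-dimethoxyphenyl in place of 2-methoxyphenyl on an amide-type nitrogen. Among the compounds with values here, the step that bears most directly on this change is the one from compound 2 to compound 3, where a single methoxy was added to the same ring: a 1.4-fold lower number from compound 2 to compound 3 (0.16 log units; within the scatter). The larger steps seen here came from swapping the acid of compound 1 for an anilide, as in a 3.4-fold higher number from compound 1 to compound 2 (0.54 log units; beyond the scatter) and a 2.4-fold higher number from compound 1 to compound 3 (0.38 log units; beyond the scatter), and that part of the molecule is unchanged between compound 3 and compound 4. Within the data shown here, with the one comparable step sitting within the scatter, no shift beyond the scatter is expected for compound 4 in this assay, so a 1.1-fold higher number from compound 3 to compound 4 (0.05 log units; within the scatter) is the estimated step. Compound 4 is therefore expected to give about 5000 nM, within a range of 2500 nM to 10000 nM.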

Compound 4, half-maximal inhibitory concentration: 4100 nM
The estimate for compound 4 lay 1.2-fold (0.09 log units) above the measured number, within the range that was stated.
By their numbers in this assay, from the lowest: compound 1; then compounds 4, 3 and 2 (each within the scatter of the next).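

In this assay, replacing 2-methoxyphenyl with 3,4-dimethoxyphenyl on the amide-type nitrogen does not move the number beyond the scatter (a 1.1-fold lower number from compound 3 to compound 4 (0.04 log units; within the scatter)), and the same holds when 3,4-dimethoxyphenyl is set against the plain phenyl (a 1.6-fold lower number from compound 2 to compound 4 (0.20 log units; within the scatter)), so these ring changes have so far produced no clear difference in this assay. The acid of compound 1 still stands apart from the new anilide (a 2.2-fold higher number from compound 1 to compound 4 (0.34 log units; beyond the scatter)), which makes compound 4 the third anilide with a step beyond the scatter from that acid, and none of the three goes against this pattern. Nothing measured here explains why the ring changes make so little difference, or why the step from the acid is larger.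

All the ring groups shown are phenyl or carry methoxy, so it remains open whether a ring bearing a nitrile, a trifluoromethyl group or an amine would give a step beyond the scatter. As far as these compounds go, it is also open whether a longer chain in the part shared by these compounds would change the number in this assay.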